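Carboxy in place of hydroxymethyl, tested a second time

The source may report more compounds than this note shows. Statements on the series, on what has been measured and on what is new or still open speak of the compounds shown alone.

Measured so far:
- compound 1, `C[C@H]1[C@H](O)C[C@@H](CCO)N[C@H]1c1ccccc1`: 41600 nM in a functional assay on DU-145 cells (Homo sapiens) for cytotoxicity, read by MTT assay; a lower number here means a stronger inhibitor, a higher number a weaker inhibitor
- compound 2, `C[C@H]1[C@H](O)C[C@@H](CC(=O)O)N[C@H]1c1ccccc1`: 46500 nM
- compound 3, `COc1ccc([C@H]2N[C@@H](CCO)C[C@H](O)[C@H]2C)cc1`: 14800 nM

Compound 1 and compound 2 share one core and differ in a single spot: carboxy in place of hydroxymethyl on a saturated chain carbon bound to a saturated ring carbon. The step that this change made is small, a 1.1-fold higher number from compound 1 to compound 2 (0.05 log units; within the scatter), so the two compounds cannot be told apart in this assay.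

Compound 3 carries a different core, and how its core differs from that of compound 1 is not broken down here. What can be said is that compound 3 gives the lowest number of the three, beyond the scatter from both compound 1 and compound 2.

Compound 4, `COc1ccc([C@H]2N[C@@H](CC(=O)O)C[C@H](O)[C@H]2C)cc1`, has not yet been measured. It stands to compound 3 as compound 2 stands to compound 1: carboxy in place of hydroxymethyl on a saturated chain carbon bound to a saturated ring carbon. The place of the change reads the same in both pairs, so it is the same change, made on a second core. For the measured compounds named here, the only guide to its effect is the one earlier step, which stayed within the scatter. On that basis compound 4 is expected to stay close to compound 3, with an estimated step of a 1.1-fold higher number from compound 3 to compound 4 (0.05 log units; within the scatter). Going by the values given here, the estimate for compound 4 in this assay is therefore 16500 nM, with a plausible range from 6500 nM to 42000 nM, the range kept wide since only a single earlier example of this change exists.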

Compound 4, half-maximal inhibitory concentration: 15700 nM
The estimate for compound 4 lay 1.1-fold (0.02 log units) above the measured number; measured number inside the range.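

On the second core the same change gives a 1.1-fold higher number from compound 3 to compound 4 (0.03 log units; within the scatter) in this assay, so carboxy and hydroxymethyl cannot be told apart on this core either. Set beside the earlier step, the change reads alike on the two cores, and in this small set the result on one core carried over to the other: the same change on two cores in this assay, a 1.1-fold higher number (0.05 log units; within the scatter) from compound 1 to compound 2 and a 1.1-fold higher number (0.03 log units; within the scatter) from compound 3 to compound 4, 1.1-fold (0.02 log units) apart, within the scatter of two such steps This is still only two pairs in one cell assay, so it does not show that the two groups would match on a third core or in any other assay, and it does not explain why the steps are so small.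

The compounds shown leave open whether a different group on a saturated chain carbon bound to a saturated ring carbon, such as an amine, an amide or a methyl ester, would shift the number beyond the scatter in this assay. They also leave open whether a longer chain ending in carboxy or hydroxymethyl would read the same as the 2-hydroxyethyl and carboxymethyl chains tested here.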